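Working notes: chloro for fluoro in compound 3

The source may report more compounds than this note shows. Statements on the series, on what has been measured and on what is new or still open speak of the compounds shown alone.

Compound 1 `O=C1/C(=C/c2ccc(F)cc2)Cc2ccccc21`: 89000 nM
Compound 2 `O=C1/C(=C/c2cccc(Cl)c2)Cc2ccccc21`: 41200 nM

Both values come from a functional assay on L1210 cells (Mus musculus) for inhibition; on this read-out lower numbers stand for stronger inhibition and higher numbers for weaker inhibition. Compound 1 holds the higher number of the two, and its gap to compound 2 lies beyond the scatter. Compound 3 `O=C1/C(=C/c2ccc(Cl)cc2)Cc2ccccc21` carries chloro in place of fluoro on an aromatic carbon, para to a large group (chloro in place of fluoro on an aromatic carbon). For the measured compounds named here, no measured pair shows this change directly. Compound 2, which also carries chloro, stands at 41200 nM, so a lower number near the edge of the scatter is expected. The expected step is a 2.0-fold lower number from compound 1 to compound 3 (0.30 log units; within the scatter). For compound 3 the estimated value is 45000 nM, with an expected range of 18000 nM to 100000 nM.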

Compound 3, half-maximal inhibitory concentration: 54100 nM
The estimate for compound 3 lay 1.2-fold (0.08 log units) below the measured number; the range from low to high includes it.
By their numbers in this assay, from the lowest: compounds 2, 3 and 1 (each within the scatter of the next, the first and the last beyond it).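

For the compounds shown here, the pair gives the first direct reading of this change: chloro in place of fluoro, on an aromatic carbon para to a large group, brings a 1.6-fold lower number from compound 1 to compound 3 (0.22 log units; within the scatter) in this assay. Exchanging these two groups at this place therefore leaves the number within the scatter. Nothing shown bears on the reason for this step.

From the compounds shown here alone, it remains open whether another group at the same place, such as methoxy, an amine or a carboxylic acid, would move the number beyond the scatter. Also open, going by these compounds, is how hydrogen at this place compares with fluoro and chloro.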